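Compound 3 and a 4-hydroxy-3,5-dimethoxyphenyl successor

The compounds below may be only part of what the source reports. "The series", "measured", "known", "first", "only" and "open" are said of these compounds alone.

In a functional assay on HepG2 cells (Homo sapiens) for antiproliferative activity, read by sulforhodamine B assay, with a stated time of 48 h (a lower number here means a stronger inhibitor, a higher number a weaker inhibitor), compound 1 `COc1ccc(OC)c(/C=C/C(=O)C(=Cc2ccc(O)c(OC)c2)C(=O)/C=C/c2cc(OC)ccc2OC)c1` gives 340 nM and compound 2 `COc1ccc(/C=C/C(=O)C(=Cc2ccc(O)c(OC)c2)C(=O)/C=C/c2ccc(OC)cc2OC)c(OC)c1` gives 510 nM. Compound 3 `COc1ccc(/C=C/C(=O)C(=Cc2ccc(O)c(F)c2)C(=O)/C=C/c2ccc(OC)cc2OC)c(OC)c1` gives 1760 nM, the highest number of the three. Compound 4 `COc1ccc(/C=C/C(=O)C(=Cc2cc(OC)c(O)c(OC)c2)C(=O)/C=C/c2ccc(OC)cc2OC)c(OC)c1` differs from it as follows: 4-hydroxy-3,5-dimethoxyphenyl in place of 3-fluoro-4-hydroxyphenyl on a double-bonded chain carbon bound to a double-bonded chain carbon. Within the data shown here, the one measured step that bears on this is a 3.5-fold higher number from compound 2 to compound 3 (0.54 log units; beyond the scatter), for fluoro in place of methoxy on an aromatic carbon, so a step of similar size in the opposite direction, toward a lower number, is expected. Among the measured compounds shown here, no measured compound shows what a further methoxy group does, which widens the range. The expected change is a 2.9-fold lower number from compound 3 to compound 4 (0.47 log units; beyond the scatter). Compound 4 is estimated at 600 nM, with an expected range from 250 nM to 1500 nM.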

Compound 4, half-maximal inhibitory concentration: 320 nM
Compound 4: middle estimate off by 1.9-fold (0.27 log units), on the high side; the range from low to high includes it.
By their numbers in this assay, from the lowest: compounds 4, 1 and 2 (each within the scatter of the next); then compound 3.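

In this assay the 4-hydroxy-3,5-dimethoxyphenyl group on a double-bonded chain carbon gives a 5.5-fold lower number from compound 3 to compound 4 (0.74 log units; beyond the scatter) and so recovers what the 3-fluoro-4-hydroxyphenyl group lost. Methoxy in place of hydrogen on an aromatic carbon gives a 1.6-fold lower number from compound 2 to compound 4 (0.20 log units; within the scatter) and so is tolerated here without a readable gain. Nothing available explains either step.

The compounds shown leave open whether the hydroxy group is needed at this position. They also leave open how an amine or a longer ethoxy chain in place of methoxy would fare.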